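Swapping Chlorine for Bromine on a Chalcone Ring

The source may hold more compounds than are shown below. What is called first, only, known or untested is meant among the compounds shown, and "the series" means these compounds.

Three compounds sharing one core were tested in a functional assay on HCT-116 cells (Homo sapiens), read by fluorescence and BrdU incorporation, with a stated time of 48 h, tested at 10 uM; on this read-out higher numbers stand for a weaker effect at the one concentration tested and lower numbers for a stronger effect. Compound 1 `COc1cc(O)c(C(=O)/C=C/c2ccc(F)cc2)c(OC)c1` gives 59%. Compound 2 `COc1cccc(/C=C/C(=O)c2c(OC)cc(OC)cc2OC)c1` gives 20%. Compound 3 `COc1cc(OC)c(C(=O)/C=C/c2ccc(Cl)cc2)c(OC)c1` gives 18%. On these numbers compound 3 sits close to compound 2, the two lying within the scatter of each other, while compound 1 stands well apart from both, its number being beyond the scatter from that of compound 3.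

For the measured compounds named here, the single one-place step among the measured compounds is a number 2 percentage points lower from compound 2 to compound 3 (within the scatter), a change that did not move the read-out beyond the scatter, and it concerns the whole aryl group rather than a single substituent on it.

Compound 4 `COc1cc(OC)c(C(=O)/C=C/c2ccc(Br)cc2)c(OC)c1` has not been measured. It differs from compound 3 by bromo in place of chloro on an aromatic carbon. Going by the values given here, no measured step addresses this exact exchange of one halogen for another, so the expectation rests on the general picture that compound 2 and compound 3 behave alike in this assay despite differing in the same region of the molecule. A step of no change at the digits printed from compound 3 to compound 4 (within the scatter) is therefore expected, that is, nothing beyond the scatter. Compound 4 is estimated to give 18%, between 7% and 32%.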

Compound 4, a percentage reported as activity, at one concentration (the size of the read-out at that concentration, not a potency): 68%
Compound 4: middle estimate off by 50 percentage points, on the low side, outside the stated range (above it).
By their numbers in this assay, from the lowest: compounds 3 and 2 (each within the scatter of the next); then compounds 1 and 4 (each within the scatter of the next).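

In this assay the exchange of chloro for bromo on this aromatic carbon, para to a large group, gives a number 50 percentage points higher from compound 3 to compound 4 (beyond the scatter) even though the swap leaves the counts of hydrogen-bond donors and acceptors unchanged, so a change of a single halogen can matter greatly at this position. The likeness of compound 2 and compound 3 therefore does not extend to every group placed here, and the wider exchange of the whole aryl group reads a number 48 percentage points higher from compound 2 to compound 4 (beyond the scatter) in the same direction, which sets 4-bromophenyl apart from both 4-chlorophenyl and 3-methoxyphenyl on this core. Nothing available here accounts for the difference between bromo and chloro at this position.

On these data alone, with only chloro and bromo compared directly on this core, it remains open whether iodo, a nitrile or an amine on the same aromatic carbon would read like chloro, like bromo or like neither. Also open, as far as these compounds go, is whether the gap between these halogens holds at other concentrations, since each compound is seen here at one concentration only and in one cell line.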